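Hydroxy for Acetoxy: Expected Effect on Growth Inhibition

The source may report more compounds than this note shows. Statements on the series, on what has been measured and on what is new or still open speak of the compounds shown alone.

Two measured compounds open this account. Compound 1 `C=C(C)CCC[C@]1(C)C2=CCC[C@](C)(C[C@H](OC(C)=O)C3=CC(=O)OC3O)[C@H]2CC[C@H]1C` was tested in a functional assay on HL-60 cells (Homo sapiens) for antiproliferative activity, read by XTT assay, with a stated time of 72 h (on this read-out higher numbers stand for weaker inhibition and lower numbers for stronger inhibition), and compound 1 gives 3000 nM there. Compound 2 `C=C(C)CCC[C@]1(C)C2=CCC[C@](C)(C[C@@H](OC(C)=O)C3=CC(=O)OC3O)[C@H]2CC[C@H]1C` differs from it only at one drawn stereocentre, and in this assay compound 2 gives 3200 nM. The step of a 1.1-fold higher number from compound 1 to compound 2 (0.03 log units; within the scatter) therefore shows no change beyond the scatter, and the pair is best read as a note on how the configuration is drawn, (the fact that one of compounds 1 and 2 is drawn with a defined configuration and the other without, at the place where they differ). Among the two numbers, compound 1 stands lowest, with compound 2 nearest.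

Compound 3 `C=C(C)CCC[C@]1(C)C2=CCC[C@](C)(C[C@H](O)C3=CC(=O)OC3O)[C@H]2CC[C@H]1C` has not been measured. It differs from compound 1 by hydrogen in place of acetyl on an oxygen on a saturated carbon. Among the compounds with values here, no measured step touches this kind of change: the only step available concerns a stereocentre, not the acetyl group, so it gives no direction for the acetoxy to hydroxy exchange. Without such guidance, the author expects compound 3 to remain in the same broad region as compound 1, with a step of a 1.3-fold higher number from compound 1 to compound 3 (0.12 log units; within the scatter) that may be modest. The estimate for compound 3 in this assay is 4000 nM, expected to lie between 1200 nM and 15000 nM.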

Compound 3, half-maximal inhibitory concentration: 3000 nM
Beside the measured number, compound 3's estimate is 1.3-fold (0.12 log units) above it; the measured number falls inside the stated range.
By their numbers in this assay, from the lowest: compounds 1, 3 and 2 (each within the scatter of the next).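

In this assay, within the data shown here, the exchange of acetoxy for hydroxy gives no change at the digits printed from compound 1 to compound 3 (within the scatter), and this is the first step in the account that touches the acetyl group rather than a drawn stereocentre. At this place, on an oxygen on a saturated carbon, the acetyl can therefore give way to hydrogen with no change beyond the scatter, so within this pair the acetyl group is not required for the number seen in compound 1. No measurement shown here bears on the reason for this result.

As far as these compounds go, what stays open is whether the oxygen itself matters at this place, a question that an amine in place of the hydroxy, or a methyl ether, would address, and whether a longer acyl chain such as butanoyl in place of the acetyl would behave like the acetyl of compound 1. Among these compounds, it also remains open whether the same exchange of acetoxy for hydroxy would read alike on the other drawn configuration, the one carried by compound 2.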